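The source may hold more compounds than are shown below. What is called first, only, known or untested is meant among the compounds shown, and "the series" means these compounds.

Three compounds have been measured in a physicochemical assay for lipophilicity; a higher number here means a more lipophilic compound, a lower number a more polar compound:
compound 1 `COC(C)CCOCn1cc[n+](C)c1/C=N/O` gives -2.22;
compound 2 `C[n+]1ccn(CCCCC#N)c1/C=N/O` gives -2.8;
compound 3 `C[n+]1ccn(CCOCCF)c1/C=N/O` gives -2.62.

Compound 1 stands highest of the three, beyond the scatter from both compound 3 and compound 2. Compound 4 `C[n+]1ccn(COCC(C)(C)CBr)c1/C=N/O` differs from compound 1 by a group of 5 heavy atoms (4 carbon, 1 bromine; no ring) in place of a group of 5 heavy atoms (4 carbon, 1 oxygen; no ring), on a saturated chain carbon bound to an oxygen on a saturated carbon. Among the compounds with values here, the only measured step, a number 0.18 log units higher from compound 2 to compound 3 (within the scatter), exchanges two groups that each keep one atom other than carbon and stays within the scatter; it gives no direct guide to a swap that drops the one hydrogen-bond acceptor of the leaving group and brings in a bromine. Because compound 1 already gives -2.22 at the top of the set, compound 4 is expected to sit somewhat higher still, a step of a number 0.72 log units higher from compound 1 to compound 4 (beyond the scatter) in this assay. The estimate for compound 4 is -1.5, with a range from -2.1 to -0.9.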

Compound 4, distribution coefficient: -0.81
For compound 4 the middle estimate is 0.69 log units below the measured one; measured number outside the range, above it.
By their numbers in this assay, from the lowest: compounds 2 and 3 (each within the scatter of the next); then compound 1; then compound 4.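

In this assay, a change on a saturated chain carbon bound to an oxygen on a saturated carbon gives a large shift, a number 1.41 log units higher from compound 1 to compound 4 (beyond the scatter), although the leaving and entering groups hold the same count of heavy atoms. Within the data shown here, the earlier compounds offered only one step, and that step stayed within the scatter. Nothing measured here accounts for the size of this shift.

Still open, going by these compounds, is how much of the shift follows the bromine itself. A chlorine or a plain methyl in place of the bromine, on the same branched chain, would separate the halogen from the carbon skeleton.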